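Swapping a Methoxyphenyl for a Furan Ring

The compounds below may be only part of what the source reports. "The series", "measured", "known", "first", "only" and "open" are said of these compounds alone.

For the measured compounds named here, compound 2 `COc1ccc(/C=C2\S/C(=N\c3nc(-c4c(C)n(C)n(-c5ccccc5)c4=O)cs3)N(c3ccccc3)C2=O)cc1` is the only compound here with a definite number in a functional assay on HepG2 cells (Homo sapiens) for cytotoxicity, read by sulforhodamine B assay, with a stated time of 72 h (a higher number here means a weaker inhibitor, a lower number a stronger inhibitor), where compound 2 gives 13200 nM. Compound 1 `Cc1c(-c2csc(/N=C3\S/C(=C\c4ccc(N(C)C)cc4)C(=O)N3c3ccccc3)n2)c(=O)n(-c2ccccc2)n1C` gives in this assay only > 100000 nM, which is a limit of the assay rather than a number. Going by the values given here, the one measured step, an at least 7.5-fold lower number from compound 1 to compound 2 (0.87 log units; beyond the scatter), concerns a different position, and its size rests on (the limit of > 100000 nM in this assay, at which 1 of the 2 values shown sits). Compound 3 `Cc1c(-c2csc(/N=C3\S/C(=C\c4ccco4)C(=O)N3c3ccccc3)n2)c(=O)n(-c2ccccc2)n1C` differs from compound 2 elsewhere: furan-2-yl in place of 4-methoxyphenyl on a double-bonded chain carbon bound to a double-bonded ring carbon. Among the compounds with values here, no measured step touches this position, so the size of the change in this assay cannot be read from the data. The expected step of a 1.5-fold higher number from compound 2 to compound 3 (0.18 log units; within the scatter) is therefore set small, with wide uncertainty. Compound 3 is expected to give about 20000 nM in this assay, within a range from 5000 nM to 100000 nM.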

Compound 3, half-maximal inhibitory concentration: 16700 nM
The estimate for compound 3 lay 1.2-fold (0.08 log units) above the measured number; measured number inside the range.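

Swapping 4-methoxyphenyl for furan-2-yl on this double-bonded chain carbon gives a 1.3-fold higher number from compound 2 to compound 3 (0.10 log units; within the scatter), so in this assay the smaller five-membered aromatic ring and the six-membered one cannot be told apart. Against the 4-(dimethylamino)phenyl group, furan-2-yl gives an at least 5.9-fold lower number from compound 1 to compound 3 (0.77 log units; beyond the scatter), so this place now has two groups that both stand clear of that one. The true size of this second step stays unknown, as the value for compound 1 is a limit and not a number: the limit of > 100000 nM in this assay, at which 1 of the 3 values shown sits.

All the groups shown at this place are aromatic rings, so it remains open whether a plain alkyl chain or a phenyl ring carrying a carboxylic acid would give a similar number. As far as these compounds go, whether the same swap would stay this small on a different core is also open.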